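The compounds below may be only part of what the source reports. "The series", "measured", "known", "first", "only" and "open" are said of these compounds alone.

Working notes on the series.

Compound 1 `O=C(CCc1cccc2c1B(O)OC2)Nc1ccccc1` and compound 2 `COc1ccc(NC(=O)CCc2cccc3c2B(O)OC3)cc1` share one core; compound 3 `COc1cccc(-c2cccc(NC(=O)CCc3ccccc3)c2)c1` and compound 4 `COc1cc(OC)cc(-c2cccc(NC(=O)CCc3ccccc3)c2)c1` share another. The difference between the two cores is not broken down here.

In an ADME assay on WI-38 cells (Homo sapiens) for cytotoxicity, read by MTT assay, with a stated time of 72 h (on this read-out lower numbers stand for stronger inhibition and higher numbers for weaker inhibition), compound 1 gives 30000 nM. Compound 2 reaches only the limit of this assay, > 100000 nM. The change from compound 1 to compound 2 is methoxy in place of hydrogen on an aromatic carbon, and it brings an at least 3.3-fold higher number from compound 1 to compound 2 (0.52 log units; beyond the scatter); the step is known only as a bound, which rests on (the limit of > 100000 nM in this assay, at which 2 of the 3 values shown sit).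

Compound 3 also reaches only the limit of this assay, > 100000 nM.

The change from compound 3 to compound 4 is methoxy in place of hydrogen on an aromatic carbon. It is the same kind of change as that from compound 1 to compound 2, but the surroundings of the place differ: in compound 2 the entering methoxy sits para to a large group, whereas in compound 4 it sits meta to a large group and meta to a methoxy group (2 heavy atoms). The change therefore occurs twice among these compounds, once measured and once to be measured.

For compound 4 the expectation is a step that the limit leaves unreadable from compound 3 to compound 4 in this assay, resting on the start of compound 3 at a limit and on the direction of the measured step from compound 1 to compound 2. Compound 4 is thus estimated at 120000 nM, most likely again as a limit rather than a number.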

Compound 4, half-maximal inhibitory concentration: > 100000 nM
Compound 4 ended at the assay's limit; the forecaster's own chance of this, stated with the estimate: 80%; the middle value lies beyond the limit too.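

In this assay compound 4 gives > 100000 nM, which is a limit and not a number. Compound 3 gives > 100000 nM, also a limit. No step between compound 3 and compound 4 can therefore be read: the limit of > 100000 nM in this assay, at which 3 of the 4 values shown sit.

The compounds shown leave open whether methoxy in place of hydrogen on an aromatic carbon changes this read-out at all on the core of compound 3.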